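Series notes: imidazole replacement, cyclohexyl to 4-cyanobenzyl

A few compounds are considered here, and "the series" means these few. Any claim that something is new, unique, unknown or untested is made for them only; others in the source may bear on it.

Measured compounds, in an in vitro functional assay on cells for agonist activity at Bombesin receptor subtype-3 (Homo sapiens), read by luminescence and calcium flux; on this read-out lower numbers stand for an effect already at smaller amounts and higher numbers for an effect only at larger amounts of compound:
- compound 1 `O=C(O)c1ccccc1-c1ccc(CCc2ncc(C3CCCCC3)[nH]2)cc1`, 375 nM
- compound 2 `CCCCc1cnc(C(CCCC)Cc2ccc(-c3ccccc3C(=O)O)cc2)[nH]1`, 2660 nM
- compound 3 `CCC(C)(C)Cc1c[nH]c(CCc2ccc(-c3ccccc3C(=O)O)cc2)n1`, 25 nM

Within these three, compound 1 carries the second highest number in this assay. Its nearest neighbour is compound 2, whose number is higher, beyond the scatter; the furthest is compound 3, whose number is lower, again beyond the scatter. Within the data shown here, no pair of measured compounds differs in a single place, so no single-step comparison is available, and the two neighbours of compound 1 differ from it in more than the group on the five-membered ring.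

Compound 4 `N#Cc1ccc(Cc2cnc(CCc3ccc(-c4ccccc4C(=O)O)cc3)[nH]2)cc1` is not yet measured. Against compound 1 the change is 4-cyanobenzyl in place of cyclohexyl on an aromatic carbon. The measured compounds give no guide for a shift from a saturated ring to an aromatic one at that position. The expectation is a small step in this assay from compound 1 to compound 4, toward a higher number, of the order a 1.6-fold higher number from compound 1 to compound 4 (0.20 log units; within the scatter), possibly within the scatter. The estimate for compound 4 is 600 nM, with a range from 150 nM to 2500 nM.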

Compound 4, half-maximal effective concentration: 5890 nM
Beside the measured number, compound 4's estimate is 9.8-fold (0.99 log units) below it, outside the stated range (above it).
By their numbers in this assay, from the lowest: compound 3; then compound 1; then compound 2; then compound 4.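

In this assay, among these compounds, the aromatic carbon of the five-membered ring proves far from tolerant of this exchange: 4-cyanobenzyl in place of cyclohexyl gives a 16-fold higher number from compound 1 to compound 4 (1.20 log units; beyond the scatter), the first comparison that differs in one place only. The step bundles several changes, with 9 heavy atoms entering against 6 leaving, an aromatic ring replacing a non-aromatic one, and a nitrile adding one hydrogen-bond acceptor where cyclohexyl has none. No measurement available here accounts for the size of this step.

The compounds shown leave open which of these changes carries the step. An unsubstituted benzyl or a cyclohexylmethyl group at the same place would separate the contributions of the nitrile, the aromatic ring and the added methylene link.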